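The compounds below may be only part of what the source reports. "The series", "measured", "known", "first", "only" and "open" are said of these compounds alone.

Measured compounds:
compound 1 `CCCOC(=O)C1=C(C)NC(=O)NC1c1ccoc1` — 11%
compound 2 `CC1=C(C(=O)OC(C)(C)C)C(c2cccs2)NC(=O)N1` — 7%
compound 3 `CCOC(=O)C1=C(C)N(C)C(=O)NC1c1cccs1` — 2%

Three compounds sharing one core were tested in an assay on membranes from HeLa cells for displacement of a labelled ligand from adenosine receptor A3 (Homo sapiens), read by scintillation counting, with a stated time of 180 min, tested at 1 uM; on this read-out higher numbers stand for more inhibition at the one concentration tested (going by the name of the read-out) and lower numbers for less inhibition. Compound 1 gives 11%, compound 2 gives 7%, and compound 3 gives 2%. All three numbers lie within the usual scatter of one another, so none of the compounds can be set apart from the others; compound 3 stands among them with no gap to either companion that exceeds the scatter.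

The unmeasured compound 4 `CC1=C(C(=O)OC(C)(C)C)C(c2cccs2)NC(=O)N1C` follows from compound 3 by one change: tert-butyl in place of ethyl on an oxygen next to a carbonyl group. Compound 2 already carries tert-butyl on that oxygen, and its value in this assay, 7%, sits no further from compound 3 than the scatter allows. On this basis compound 4 is expected to stay within the scatter, with an estimated step of a number 3 percentage points higher from compound 3 to compound 4 (within the scatter), in no direction beyond it. For compound 4 the estimate in this assay is 5%, expected between -5% and 15%.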

Compound 4, a percentage reported as inhibition, at one concentration (the size of the read-out at that concentration, not a potency): 22%
Compound 4: the middle estimate sits 17 percentage points below what was measured, and the stated range ends below it.
By their numbers in this assay, from the lowest: compounds 3, 2 and 1 (each within the scatter of the next); then compound 4.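

In this assay, tert-butyl in place of ethyl on an oxygen next to a carbonyl group gives a number 20 percentage points higher from compound 3 to compound 4 (beyond the scatter) and methyl in place of hydrogen on an amide-type nitrogen in a ring gives a number 15 percentage points higher from compound 2 to compound 4 (beyond the scatter) in the same read-out. Going by these compounds alone, these are the first single-place steps in this set, and they show that each change can move the number when the other group is present, at this one concentration. No measurement at hand bears on why either step arises.

The compounds shown leave open whether tert-butyl in place of ethyl gives a step of this size when the hydrogen stays on that nitrogen. They also leave open what a longer chain on that nitrogen, or a benzyl group or a carboxylic acid in place of tert-butoxycarbonyl, would give.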